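The source may hold more compounds than are shown below. What is called first, only, known or untested is meant among the compounds shown, and "the series" means these compounds.

Working notes on the series.

Two compounds carry measurements in a functional assay on the whole organism with Mus musculus as the target; a lower number here means that less compound is needed, a higher number that more compound is needed for the effect. Going by the values given here, compound 1, `Cn1nc(-c2cccc(C(F)(F)F)c2)n(C)c1=S`, gives only a limit of the assay, > 200 mg/kg; this is the single boundary value in the set, (the limit of > 200 mg/kg in this assay, at which 1 of the 2 values shown sits). Compound 2, `Cn1nc(-c2ccccc2Cl)n(C)c1=S`, gives 0.58 mg/kg in this assay, the only actual number shown so far. Among the compounds with values here, with no second number, no measured step exists between compound 1 and compound 2, and nothing beyond the two readings themselves can be said about that pair.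

Compound 3, `Cn1nc(-c2ccccc2)n(C)c1=S`, is the next point. It differs from compound 2 by hydrogen in place of chloro on an aromatic carbon: the chloro group on an aromatic carbon of the six-membered carbon-only ring, ortho to a group of 8 heavy atoms, is replaced by hydrogen. Since compound 1 sits at the limit and compound 2 carries a halogen on that ring, a loss of the chloro is expected to weaken the effect, and the step from compound 2 to compound 3 is estimated at a 3.4-fold higher number from compound 2 to compound 3 (0.54 log units; beyond the scatter) in this assay, beyond the usual scatter. Compound 3 is accordingly expected to give about 2 mg/kg, in a range from 0.5 mg/kg to 10 mg/kg.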

Compound 3, dose for half-maximal effect: 0.13 mg/kg
Compound 3: middle estimate off by 15-fold (1.19 log units), on the high side; measured number outside the range, below it.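

Hydrogen in place of chloro on an aromatic carbon, ortho to a group of 8 heavy atoms, gives a 4.5-fold lower number from compound 2 to compound 3 (0.65 log units; beyond the scatter) in this assay, so the effect at this position does not depend on the chloro. Hydrogen in place of trifluoromethyl on an aromatic carbon gives an at least 1500-fold lower number from compound 1 to compound 3 (3.18 log units; beyond the scatter), so among the compounds shown, neither substituent improves on hydrogen. The second step has only a lower bound on its size, as one end of it is a limit of the assay: the limit of > 200 mg/kg in this assay, at which 1 of the 3 values shown sits.

From the compounds shown here alone, whether a small group such as methyl or fluoro, or a larger one such as methoxy or an amine, would match hydrogen at the position of the chloro remains open. Also open, going by these compounds, is how much of the step from trifluoromethyl reflects the group itself and how much its place on the ring.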